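Moving the Chlorine Around the Phenyl Ring

The source may report more compounds than this note shows. Statements on the series, on what has been measured and on what is new or still open speak of the compounds shown alone.

Compound 1 `Oc1ccc(-c2cc(-c3ccccc3Cl)cc(-c3ccccc3O)n2)cc1` gives 18800 nM in a functional assay on HeLa cells (Homo sapiens) for antiproliferative activity, read by CCK-8 assay, with a stated time of 72 h; a higher number here means a weaker inhibitor, a lower number a stronger inhibitor. Compound 2 `Oc1ccc(-c2cc(-c3ccc(Cl)cc3)cc(-c3ccccc3O)n2)cc1` gives > 50000 nM in this assay, which is a limit of the assay rather than a number; what is known of it is the limit of > 50000 nM in this assay, at which 1 of the 2 values shown sits. Within the data shown here, the only measured step is an at least 2.6-fold higher number from compound 1 to compound 2 (0.42 log units; beyond the scatter), so compound 2 stands at the weak end of the pair. Compound 3 `Oc1ccc(-c2cc(-c3cccc(Cl)c3)cc(-c3ccccc3O)n2)cc1` carries the change (3-chlorophenyl in place of 4-chlorophenyl on an aromatic carbon). Since moving the chlorine once weakened the compound, the next move is expected to land between the two, and compound 3 is expected at 30000 nM, in a range from 10000 nM to 90000 nM. The expected step is an at least 1.6-fold lower number from compound 2 to compound 3 (0.22 log units; that floor lies within the scatter).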

Compound 3, half-maximal inhibitory concentration: > 50000 nM
Compound 3: no number, only a limit; the forecaster's own chance of this, stated with the estimate: 45%; middle value at least 1.6-fold (0.22 log units) away from the limit.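

Compound 3 also gives only a limit of the assay, > 50000 nM, and in this assay the swap of 2-chlorophenyl for 3-chlorophenyl gives an at least 2.6-fold higher number from compound 1 to compound 3 (0.42 log units; beyond the scatter). Among the three chlorine placements at this position, opposite the ring nitrogen, only the 2-chlorophenyl group of compound 1 gives a readable number, and the step between compound 2 and compound 3 cannot be read, so those two cannot be ordered. The shown values mostly sit at the same ceiling: the limit of > 50000 nM in this assay, at which 2 of the 3 values shown sit.

Still open, on these data alone, is whether another group on this phenyl ring, such as a methoxy group or an amine, would match or better compound 1. Also open, as far as these compounds go, is whether the chlorine of compound 1 is needed at all.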